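The compounds below may be only part of what the source reports. "The series", "measured", "known", "first", "only" and "open" are said of these compounds alone.

Compound 1 `CC(C)(C)Sc1c(CC(C)(C)C(=O)O)n(Cc2ccc(Cl)cc2)c2ccc(OCc3ccc4cnccc4n3)cc12`: 3 nM
Compound 2 `CC(C)(C)Sc1c(CC(C)(C)C(=O)O)n(Cc2ccc(Cl)cc2)c2ccc(OCc3ccncc3)cc12`: 6 nM

In a functional assay for inhibition, with Homo sapiens as the target (a lower number here means a stronger inhibitor, a higher number a weaker inhibitor), compound 2 gives 6 nM, the higher of the two numbers shown, yet the gap to compound 1 with 3 nM lies within the usual scatter, so the two are not really told apart. Compound 3 `CC(C)c1csc(COc2ccc3c(c2)c(SC(C)(C)C)c(CC(C)(C)C(=O)O)n3Cc2ccc(Cl)cc2)n1` has not been measured. It differs from compound 2 by 4-isopropyl-1,3-thiazol-2-yl in place of pyridin-4-yl on a saturated chain carbon bound to an oxygen on an aromatic ring. Among the compounds with values here, only one measured step bears on this: a 2.0-fold higher number from compound 1 to compound 2 (0.30 log units; within the scatter), where one aromatic ring gave way to another on the saturated chain carbon bound to an oxygen on an aromatic ring and the number stayed within the scatter. Since the change to compound 3 again swaps the ring at this place, no step beyond the scatter is expected, no change at the digits printed from compound 2 to compound 3 (within the scatter). Compound 3 is therefore estimated at 6 nM, with a range from 2 nM to 20 nM.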

Compound 3, half-maximal inhibitory concentration: 3 nM
Compound 3: the middle estimate sits 2.0-fold (0.30 log units) above what was measured; low and high end bracket the measured number.
By their numbers in this assay, from the lowest: compounds 1, 3 and 2 (each within the scatter of the next).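

In this assay the step to 4-isopropyl-1,3-thiazol-2-yl reads a 2.0-fold lower number from compound 2 to compound 3 (0.30 log units; within the scatter) and the step from the two-ring group reads no change at the digits printed from compound 1 to compound 3 (within the scatter) so all three compounds remain within the scatter of one another. The earlier pair showed only six-membered rings at this place, whereas compound 3 shows that a five-membered aromatic ring with sulfur among its hetero atoms and an isopropyl group attached also fits this range of numbers. No measured evidence is available to explain this result.

On these data alone, whether this place also accepts a group without an aromatic ring, such as an aminomethyl group or a carboxylic acid, remains open. Also open is how much the isopropyl group contributes, since a plain 1,3-thiazol-2-yl group is not among the compounds shown.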